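A methoxy group moves among compounds at the assay limit

The compounds below may be only part of what the source reports. "The series", "measured", "known", "first", "only" and "open" are said of these compounds alone.

Measured in a functional assay on Jurkat cells (Homo sapiens) for cytotoxicity, with a stated time of 24 h; on this read-out lower numbers stand for stronger inhibition and higher numbers for weaker inhibition:
- Compound 1 `Nn1c(SCc2ccc([N+](=O)[O-])cc2)nnc1-c1c[nH]c2ccccc12`: > 100000 nM, a limit
- Compound 2 `Nn1c(SCc2ccc(Br)cc2)nnc1-c1c[nH]c2ccccc12`: > 100000 nM, a limit
- Compound 3 `COc1cccc(CSc2nnc(-c3c[nH]c4ccccc34)n2N)c1`: > 100000 nM, a limit

Compound 3 gives only a limit here, not a number. The same is true across this small set, which shares one reading: the limit of > 100000 nM in this assay, at which 3 of the 3 values shown sit.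

The unmeasured compound 4 `COc1ccc(CSc2nnc(-c3c[nH]c4ccccc34)n2N)cc1` has 4-methoxyphenyl in place of 3-methoxyphenyl on a saturated chain carbon bound to a sulfur.

Two measured changes to the same group bear on this one: a step that the two limits leave unreadable from compound 1 to compound 2 and a step that the two limits leave unreadable from compound 2 to compound 3. Neither gives a size to carry over, but neither brought a compound off the limit. Compound 4 is therefore expected to stay close to the same limit because of the limit of > 100000 nM in this assay, at which 3 of the 3 values shown sit. The estimated a number no higher from compound 3 to compound 4 (the limit leaves the size open) is no step beyond the scatter in this assay, and a further limit is the likeliest report. For compound 4 the estimate is 100000 nM, with an expected range from 40000 nM to 200000 nM.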

Compound 4, half-maximal inhibitory concentration: > 100000 nM
Compound 4: no number, only a limit; the forecaster's own chance of this, stated with the estimate: 80%; the middle value lies on the limit itself.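

In this assay compound 4 gives > 100000 nM, which is a limit and not a number. Going by these compounds alone, no step from compound 1, compound 2 or compound 3 to compound 4 can be read. The compounds shown leave open what change, if any, would bring a compound off this limit and give a measurable number.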